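The source may report more compounds than this note shows. Statements on the series, on what has been measured and on what is new or still open speak of the compounds shown alone.

Compound 1 `O=C(CSc1nc(Nc2ccccc2)c2ccccc2n1)Nc1cccc([N+](=O)[O-])c1`: 28100 nM
Compound 2 `O=C(CSc1nc(Nc2ccccc2)c2ccccc2n1)Nc1ccc(C(F)(F)F)cc1`: 8670 nM

In a functional assay on MGC-803 cells (Homo sapiens) for inhibition, read by MTT assay, with a stated time of 72 h (a higher number here means a weaker inhibitor, a lower number a stronger inhibitor), compound 1 gives 28100 nM, the highest of the two numbers recorded; its nearest neighbour, compound 2, gives 8670 nM. For the measured compounds named here, the only step measured so far, a 3.2-fold lower number from compound 1 to compound 2 (0.51 log units; beyond the scatter), arises from a single exchange on the amide-type nitrogen and lies beyond the scatter.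

Compound 3 `O=C(CSc1nc(Nc2ccccc2)c2ccccc2n1)Nc1ccc(Cl)cc1Cl` is not yet measured. It differs from compound 1 in one place: 2,4-dichlorophenyl in place of 3-nitrophenyl on an amide-type nitrogen. Going by the values given here, the step from compound 1 to compound 2 is the only measured step that bears on this change, since both replace the same 3-nitrophenyl on the same amide-type nitrogen with another aryl group. On that basis a lowering of the number in this assay of roughly similar size is expected for compound 3, that is a 2.8-fold lower number from compound 1 to compound 3 (0.45 log units; beyond the scatter). Compound 3 is therefore estimated at 10000 nM, with a range from 4000 nM to 25000 nM.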

Compound 3, half-maximal inhibitory concentration: 12300 nM
Compound 3: the middle estimate sits 1.2-fold (0.09 log units) below what was measured, within the range that was stated.
By their numbers in this assay, from the lowest: compounds 2 and 3 (each within the scatter of the next); then compound 1.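

With 2,4-dichlorophenyl on the amide-type nitrogen, this assay shows a 2.3-fold lower number from compound 1 to compound 3 (0.36 log units; beyond the scatter) and thus a second replacement for 3-nitrophenyl that lowers the number, so the earlier drop is not unique to 4-(trifluoromethyl)phenyl. Between the two replacements there is a 1.4-fold higher number from compound 2 to compound 3 (0.15 log units; within the scatter) and so no distinction can be drawn between 2,4-dichlorophenyl and 4-(trifluoromethyl)phenyl at this position. No supporting measurement is available to account for these differences.

The compounds shown leave open how an unsubstituted phenyl, or a phenyl carrying an amine or a carboxylic acid, would behave on this nitrogen. From the compounds shown here alone, it is also open whether a simple alkyl group such as methyl could replace the aryl ring, and how changes to the shared core would affect the number.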